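The source may hold more compounds than are shown below. What is called first, only, known or untested is meant among the compounds shown, and "the series" means these compounds.

Going by the values given here, compound 2 `N#Cc1c(N)nc(SCc2nc3ccccc3[nH]2)c(C#N)c1-c1ccc(OCC2CC2)cc1` stands highest of the two numbers so far in an assay on CHO cells for displacement of a labelled ligand from adenosine receptor A1 (Homo sapiens), read by scintillation counting, with a stated time of 90 min, tested at 1 uM (a higher number here means more inhibition at the concentration tested (going by the name of the read-out), a lower number less inhibition), where compound 2 gives 21%. Among the compounds with values here, its nearest neighbour is compound 1 `N#Cc1c(N)nc(SCc2nnn[nH]2)c(C#N)c1-c1ccc(OCC2CC2)cc1`, which in this assay gives 3%; the one measured step, a number 18 percentage points higher from compound 1 to compound 2 (beyond the scatter), came with 1H-benzimidazol-2-yl in place of 1H-tetrazol-5-yl on a saturated chain carbon bound to a sulfur.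

Compound 3 `CNC(=O)CSc1nc(N)c(C#N)c(-c2ccc(OCC3CC3)cc2)c1C#N` is not yet measured in this assay. It differs from compound 2 in one place: methylcarbamoyl in place of 1H-benzimidazol-2-yl on a saturated chain carbon bound to a sulfur.

Within the data shown here, no measured step bears directly on this exchange. Among the measured compounds shown here, the step from compound 1 to compound 2 shows only that the group on the saturated chain carbon bound to a sulfur moves the number by a modest amount, with 1H-benzimidazol-2-yl giving the higher of the two. Methylcarbamoyl carries neither ring of the leaving group, so the number for compound 3 is expected to fall back, as a step of a number 13 percentage points lower from compound 2 to compound 3 (beyond the scatter), toward the low end seen for compound 1. For compound 3 the estimate in this assay is 8%, with a range from 0% to 25%.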

Compound 3, a percentage reported as inhibition, at one concentration (the size of the read-out at that concentration, not a potency): 14%
Beside the measured number, compound 3's estimate is 6 percentage points below it, within the range that was stated.
By their numbers in this assay, from the lowest: compound 1; then compounds 3 and 2 (each within the scatter of the next).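

In this assay, methylcarbamoyl in place of 1H-benzimidazol-2-yl on a saturated chain carbon bound to a sulfur gives a number 7 percentage points lower from compound 2 to compound 3 (within the scatter) and so shows that a group with no ring cannot be told apart here from one with two aromatic rings. The step of a number 11 percentage points higher from compound 1 to compound 3 (beyond the scatter) then shows that the earlier difference does not depend on a fused aromatic group, since compound 1 with 1H-tetrazol-5-yl now stands apart from both other compounds, each step to them being beyond the scatter. Nothing available gives a reason for this difference at the position.

Open at this position is whether a carboxylic acid, a primary carboxamide or dimethylcarbamoyl would stay with compound 3 or fall toward compound 1, and whether a longer chain between the sulfur and the methylcarbamoyl would change the reading. Also open, as far as these compounds go, is whether a simple phenyl or an imidazol-2-yl would read with 1H-benzimidazol-2-yl or with 1H-tetrazol-5-yl, and single-concentration numbers of this size give no potency for any of the three compounds.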